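Replacing cycloheptyl with a branched phenylalkyl chain

A few compounds are considered here, and "the series" means these few. Any claim that something is new, unique, unknown or untested is made for them only; others in the source may bear on it.

Compound 3 `C/C(=N\OC(c1ccc(OCc2ccc3ccccc3n2)cc1)C1CCCCCC1)C(=O)O` gives 13 nM in a functional assay for inhibition of Polyunsaturated fatty acid 5-lipoxygenase (Homo sapiens) (on this read-out higher numbers stand for weaker inhibition and lower numbers for stronger inhibition), the lowest of the three numbers recorded, though both neighbours sit within the scatter of it: compound 1 `CCCCC(CCCC)C(O/N=C(\C)C(=O)O)c1ccc(OCc2ccc3ccccc3n2)cc1` gives 14 nM and compound 2 `O=C(O)/C=N/OC(c1ccc(OCc2ccc3ccccc3n2)cc1)C1CCCCCC1` gives 18 nM. The step of a 1.1-fold lower number from compound 1 to compound 3 (0.03 log units; within the scatter) and the step of a 1.4-fold lower number from compound 2 to compound 3 (0.14 log units; within the scatter) both stayed inside the scatter. Compound 4 `C/C(=N\OC(CC(C)(C)c1ccccc1)c1ccc(OCc2ccc3ccccc3n2)cc1)C(=O)O` differs from compound 3 by 2-methyl-2-phenylpropyl in place of cycloheptyl on a saturated chain carbon bound to an aromatic carbon and an oxygen. Among the measured compounds shown here, the one measured step at this same place, a 1.1-fold lower number from compound 1 to compound 3 (0.03 log units; within the scatter), exchanged one group for another with no effect beyond the scatter, so for this assay the expected step is a 1.2-fold higher number from compound 3 to compound 4 (0.06 log units; within the scatter), essentially no movement. Compound 4 is therefore estimated at 15 nM, with a range from 6 nM to 40 nM.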

Compound 4, half-maximal inhibitory concentration: 22 nM
Estimate against measurement, compound 4: 1.5-fold (0.17 log units) below; the measured number falls inside the stated range.
By their numbers in this assay, from the lowest: compounds 3, 1, 2 and 4 (each within the scatter of the next).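

In this assay, this saturated chain carbon bound to an aromatic carbon and an oxygen now carries a group with a six-membered aromatic ring, and the number stays within the scatter of both earlier groups: 2-methyl-2-phenylpropyl gives a 1.7-fold higher number from compound 3 to compound 4 (0.23 log units; within the scatter) against cycloheptyl and a 1.6-fold higher number from compound 1 to compound 4 (0.20 log units; within the scatter) against 1-butylpentyl. No measurement shown bears on this result.

As far as these compounds go, whether an amine or a hydroxyl group at this place would move the number beyond the scatter remains open. So does whether 2-methyl-2-phenylpropyl would give a similar number on the core of compound 2.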